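From 4-iodophenyl to 3-bromophenyl: a small expected step

A few compounds are considered here, and "the series" means these few. Any claim that something is new, unique, unknown or untested is made for them only; others in the source may bear on it.

For the measured compounds named here, in a functional assay on CCRF-CEM cells (Homo sapiens) for cytotoxicity, read by MTT assay, with a stated time of 96 h (a higher number here means that more compound is tolerated, a lower number that less compound is tolerated), compound 1 `FC(F)(F)c1cccc(NC(=S)Nc2ccc(I)cc2)c1` gives 8000 nM and has only one measured neighbour so far. That neighbour is compound 2 `N#Cc1ccc(NC(=S)Nc2cccc(C(F)(F)F)c2)cc1` at 8700 nM and the two values lie within the scatter of each other. Going by the values given here, the unmeasured compound 3 `FC(F)(F)c1cccc(NC(=S)Nc2cccc(Br)c2)c1` keeps the rest of compound 1 and carries 3-bromophenyl in place of 4-iodophenyl on an amide-type nitrogen as its single change. Among the compounds with values here, the one measured step that bears on this is cyano in place of iodo on an aromatic carbon, which gives a 1.1-fold higher number from compound 1 to compound 2 (0.04 log units; within the scatter) and so offers a first hint that this part of the structure can change with little effect on the number. Within the data shown here, it is a single example, however, and no measured compound carries 3-bromophenyl, so the hint is weak. No step beyond the scatter is therefore expected in this assay for this change. The estimate means a 1.1-fold lower number from compound 1 to compound 3 (0.03 log units; within the scatter) as the expected step. Compound 3 is expected at 7500 nM with an estimated range from 3000 nM to 18000 nM in this measurement.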

Compound 3, half-maximal cytotoxic concentration: 9300 nM
Estimate against measurement, compound 3: 1.2-fold (0.09 log units) below, within the range that was stated.
By their numbers in this assay, from the lowest: compounds 1, 2 and 3 (each within the scatter of the next).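

In this assay, putting 3-bromophenyl in place of 4-iodophenyl on the amide-type nitrogen gives a 1.2-fold higher number from compound 1 to compound 3 (0.07 log units; within the scatter), so a second change at this place also stays within the scatter. The earlier step replaced iodo with cyano on an aromatic carbon and kept that carbon the same, whereas here both the halogen and its place on the ring differ, and the numbers still stay close, so this part of the structure has now tolerated two different changes without a step beyond the scatter, although this single step cannot separate the effect of the halogen from that of its place. No measured information on these groups accompanies this result, so the data give no explanation for it.

Going by these compounds, all three compounds keep the trifluoromethyl group and the thiocarbonyl carbon, so the effect of changing those parts remains open. Also open, on these data alone, is whether 3-iodophenyl or 4-bromophenyl would separate the halogen from its place, and whether a phenyl group carrying an amine or a carboxylic acid would also stay within the scatter.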